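Another phenyl group on the ring nitrogen: no shift expected

The source may hold more compounds than are shown below. What is called first, only, known or untested is meant among the compounds shown, and "the series" means these compounds.

Measured so far:
- compound 1, `Nc1scc(CN2CCN(c3ccc(Cl)cc3Cl)CC2)c1C(=O)c1ccc(Cl)cc1`, gives 0%
- compound 2, `Nc1scc(CN2CCN(c3cc(Cl)cc(Cl)c3)CC2)c1C(=O)c1ccc(Cl)cc1`, gives 1%
- compound 3, `Nc1scc(CN2CCN(c3cccc(C(F)(F)F)c3)CC2)c1C(=O)c1ccc(Cl)cc1`, gives 0%

All three results come from an assay on CHO cells for displacement of a labelled ligand from adenosine receptor A3 (Homo sapiens), read by scintillation counting, with a stated time of 120 min, tested at 10 uM; on this read-out higher numbers stand for more inhibition at the one concentration tested (going by the name of the read-out) and lower numbers for less inhibition. Compound 1 stands level with compound 3 at the digits shown, and the two together are the lowest of the three numbers; compound 2 is the furthest from compound 1, yet the gap between them stays within the usual scatter. In short, none of the three compounds shows any inhibition worth the name at the single concentration tested.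

Compound 4, `Nc1scc(CN2CCN(c3ccc(OC(F)(F)F)cc3)CC2)c1C(=O)c1ccc(Cl)cc1`, is the next compound to be tested. Relative to compound 1 the change is 4-(trifluoromethoxy)phenyl in place of 2,4-dichlorophenyl on an amine nitrogen in a ring.

Among the compounds with values here, two measured steps bear on this change, since both also exchange the group on the ring nitrogen of the shared core: a number 1 percentage points higher from compound 1 to compound 2 (within the scatter) and no change at the digits printed from compound 1 to compound 3 (within the scatter). Both steps lie within the scatter, so the exchange of this phenyl group has so far left the read-out flat. The expected step is therefore a number 1 percentage points higher from compound 1 to compound 4 (within the scatter), that is, no step beyond the scatter. Compound 4 is estimated at 1%, with a range from 0% to 9%.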

Compound 4, a percentage reported as inhibition, at one concentration (the size of the read-out at that concentration, not a potency): 1%
Beside the measured number, compound 4's estimate shows no gap at the digits printed, within the range that was stated.
By their numbers in this assay, from the lowest: compounds 1, 3, 2 and 4 (each within the scatter of the next).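

The earlier compounds shown here varied only chlorine and trifluoromethyl groups on the phenyl ring, whereas 4-(trifluoromethoxy)phenyl brings in oxygen and a hydrogen-bond acceptor, with 11 heavy atoms against 8 for the 2,4-dichlorophenyl it replaces. Even this different group leaves this assay flat across the four compounds, the steps being a number 1 percentage points higher from compound 1 to compound 4 (within the scatter), a number 1 percentage points higher from compound 3 to compound 4 (within the scatter) and no change at the digits printed from compound 2 to compound 4 (within the scatter). No outside measurement is available to explain why inhibition stays so slight for this set.

From the compounds shown here alone, all four compounds carry a substituted phenyl group on this ring nitrogen, so it remains open whether a different kind of group there, such as a benzyl group or a longer chain ending in a carboxylic acid, would give any real inhibition at all. Going by these compounds, with every number close to nothing at the one concentration tested, it also remains open whether these phenyl groups differ from one another in a way that a full concentration series could reveal.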